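The compounds below may be only part of what the source reports. "The series", "measured", "known", "first", "only" and "open" are said of these compounds alone.

Three compounds built on one shared core have been examined in an ADME assay on SW480 cells (Homo sapiens) for cytotoxicity, read by MTT assay, with a stated time of 72 h; on this read-out higher numbers stand for weaker inhibition and lower numbers for stronger inhibition. Compound 1 `Cc1ccc(NC(=O)c2cccc(/C=C3\CC(=O)N(c4ccccc4)C3=O)c2)cc1` gives only a limit of the assay there, > 100000 nM. Compound 2 `O=C(Nc1ccc(OC(F)F)cc1)c1cccc(/C=C2\CC(=O)N(c3ccccc3)C2=O)c1` likewise gives only a limit, > 100000 nM. Compound 3 `O=C(c1cccc(/C=C2\CC(=O)N(c3ccccc3)C2=O)c1)N1CCCC1` also returns only a limit, > 100000 nM. Compound 3 therefore stands where its two companions stand: at a limit rather than at a number, and nothing in these results sets it apart from them. The steps a step that the two limits leave unreadable from compound 1 to compound 2, a step that the two limits leave unreadable from compound 1 to compound 3 and a step that the two limits leave unreadable from compound 2 to compound 3 are all of unreadable size, and the one thing the data show is the limit of > 100000 nM in this assay, at which 3 of the 3 values shown sit.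

Compound 4 `O=C(Nc1ccc(Cl)cc1)c1cccc(/C=C2\CC(=O)N(c3ccccc3)C2=O)c1` differs from compound 3 by (4-chlorophenyl)amino in place of pyrrolidin-1-yl on a carbonyl carbon. The two measured steps that touch the same carbonyl carbon, a step that the two limits leave unreadable from compound 1 to compound 3 and a step that the two limits leave unreadable from compound 2 to compound 3, exchange a substituted phenylamino group for pyrrolidin-1-yl, the reverse of the present change, and both were left unreadable by the limits; the step of a number no higher from compound 3 to compound 4 (the limit leaves the size open) is thus expected to be no more than scatter, with a limit the most likely outcome. Compound 4 is accordingly estimated at 100000 nM, within a range from 30000 nM to 300000 nM.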

Compound 4, half-maximal inhibitory concentration: > 100000 nM
Compound 4 gave a limit, no number; the forecaster's own chance of this, stated with the estimate: 80%; the middle value lies on the limit itself.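

Compound 4 also returns only a limit in this assay, > 100000 nM, so no new step can be read between it and compound 1, compound 2 or compound 3. The compounds shown leave open whether the groups on the carbonyl carbon differ at all in this assay, and none of them yields a number: the limit of > 100000 nM in this assay, at which 4 of the 4 values shown sit.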